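A whole aromatic group swapped after three small changes

A few compounds are considered here, and "the series" means these few. Any claim that something is new, unique, unknown or untested is made for them only; others in the source may bear on it.

compound 1 `CC1=C(c2nc(-c3ccc(C#N)cc3)cs2)C(c2ccc(F)nc2)NC(=O)N1` gives 100%
compound 2 `CC1=C(c2nc(-c3ccc(C#N)cc3)cs2)C(c2ccc(Cl)nc2)NC(=O)N1` gives 91.7%
compound 3 `CC1=C(c2nc(-c3ccc(C#N)cc3)cs2)C(c2ccc(Br)nc2)NC(=O)N1` gives 98.3%

In an ADME assay on a cell-free system (plasma, Rattus norvegicus) for metabolic stability, read by LC-MS, with a stated time of 1 h, tested at 100 uM (on this read-out lower numbers stand for a less stable compound and higher numbers for a more stable compound), compound 3 gives 98.3% and cannot be told apart from the other two compounds. The steps that reach it are a number 1.7 percentage points lower from compound 1 to compound 3 (within the scatter) and a number 6.6 percentage points higher from compound 2 to compound 3 (within the scatter) and so it stands level with both.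

Compound 4 `COc1ccc(C2NC(=O)NC(C)=C2c2nc(-c3ccc(C#N)cc3)cs2)cc1` differs from compound 3 in a whole group (4-methoxyphenyl in place of 6-bromopyridin-3-yl on a saturated ring carbon) with 4-methoxyphenyl in place of 6-bromopyridin-3-yl on a saturated ring carbon. Going by the values given here, the only measured steps that bear on this are swaps among fluoro, chloro and bromo on an aromatic carbon. Besides the two above there is a number 8.3 percentage points lower from compound 1 to compound 2 (within the scatter) and all three stay within the scatter. None of them replaces the whole group, so they guide the expectation only loosely. In this assay no step beyond the scatter is expected, and the range reaches further down than up because compound 3 at 98.3% leaves little room upward. The expected step is a number 3.3 percentage points lower from compound 3 to compound 4 (within the scatter) (an estimate, not a measurement). For compound 4 the estimated value is 95% (expected range 80% to 100%).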

Compound 4, percent of the compound remaining: 96%
Compound 4: the middle estimate sits 1 percentage points below what was measured; measured number inside the range.
By their numbers in this assay, from the lowest: compounds 2, 4, 3 and 1 (each within the scatter of the next).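

In this assay, replacing a whole aromatic group on the saturated ring carbon changes the read-out no more than the halogen swaps did: the steps are a number 2.3 percentage points lower from compound 3 to compound 4 (within the scatter) and a number 4.3 percentage points higher from compound 2 to compound 4 (within the scatter) and a number 4 percentage points lower from compound 1 to compound 4 (within the scatter). The earlier compounds shown here showed only that one halogen could stand in for another on the pyridine ring, whereas compound 4 has neither halogen nor ring nitrogen and carries 4-methoxyphenyl, yet remains level with all three. Nothing available explains why the read-out stays level across these changes.

All four compounds sit close to the top of the scale, so no group at this position has yet been seen to lower the number clearly. On these data alone, whether a carboxylic acid, an amine or a longer chain on the aromatic ring would leave it level remains open.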